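From compound 2 to compound 3 at the limit

A few compounds are considered here, and "the series" means these few. Any claim that something is new, unique, unknown or untested is made for them only; others in the source may bear on it.

Compound 1 `COc1ccccc1/C=C/C(=O)c1ccc(OC)c2c1OC(C)(C)C=C2`: > 10000 nM, a limit
Compound 2 `COc1ccc(C(=O)/C=C/c2cccc(O)c2)c2c1C=CC(C)(C)O2`: > 10000 nM, a limit

In a functional assay on HepG2 cells (Homo sapiens) for antiproliferative activity, read by MTT assay, with a stated time of 24 h (a higher number here means a weaker inhibitor, a lower number a stronger inhibitor), compound 2 has no exact number, only the limit > 10000 nM. The whole record so far is the limit of > 10000 nM in this assay, at which 2 of the 2 values shown sit.

Compound 3 `COc1ccc(C(=O)/C=C/c2cc(Cl)ccc2O)c2c1C=CC(C)(C)O2` differs from compound 2 as follows: 5-chloro-2-hydroxyphenyl in place of 3-hydroxyphenyl on a double-bonded chain carbon bound to a double-bonded chain carbon. Thus 5-chloro-2-hydroxyphenyl takes the place of 3-hydroxyphenyl on a double-bonded chain carbon bound to a double-bonded chain carbon.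

Among the measured compounds shown here, the only measured step, at the same place, is a step that the two limits leave unreadable from compound 1 to compound 2. With no size to carry over, no step beyond the scatter is expected in this assay, and no direction can be expected either. The expected step is a step that the limit leaves unreadable from compound 2 to compound 3. For compound 3 the estimated value is 15000 nM, with an expected range from 4000 nM to 50000 nM.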

Compound 3, half-maximal inhibitory concentration: 6640 nM
For compound 3 the middle estimate is 2.3-fold (0.35 log units) above the measured one, within the range that was stated.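

Among the compounds shown here, at the double-bonded chain carbon bound to a double-bonded chain carbon, 5-chloro-2-hydroxyphenyl gives the first exact reading in this assay, where the earlier compounds gave only limits. Putting it in place of 3-hydroxyphenyl is an at least 1.5-fold lower number from compound 2 to compound 3 (0.17 log units; that floor lies within the scatter), and putting it in place of 2-methoxyphenyl is an at least 1.5-fold lower number from compound 1 to compound 3 (0.17 log units; that floor lies within the scatter). Each of these steps gives only a floor, so its true size stays unknown, and most of the record still rests on a limit: the limit of > 10000 nM in this assay, at which 2 of the 3 values shown sit.

Which part of 5-chloro-2-hydroxyphenyl carries the reading stays open, and a plain 2-hydroxyphenyl group would separate the chlorine from the rest. Also open, on these data alone, is whether an amine or a carboxylic acid in place of the chlorine would keep, lower or raise the number.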